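Amine substituent variation across a shared core

The source may hold more compounds than are shown below. What is called first, only, known or untested is meant among the compounds shown, and "the series" means these compounds.

Three compounds of the series have numbers in a functional assay on MDA-MB-231 cells (Homo sapiens) for inhibition, with a stated time of 48 h; a higher number here means that more compound is needed for the effect, a lower number that less compound is needed. Compound 1 `CCCCCCCCCCCCCCCCSCc1cc(CSC[C@H](NC(=O)[C@H](C)NC)C(=O)N2CCC[C@H]2C(=O)NC(c2ccccc2)c2ccccc2)cc(CSC[C@H](NC(=O)[C@H](C)NC)C(=O)N2CCC[C@H]2C(=O)NC(c2ccccc2)c2ccccc2)c1` gives 11300 nM in this assay. Compound 2 `CCCCCCCCCCCCCCCC(=O)NCCCC[C@H](NC(=O)[C@H](C)NC)C(=O)N1CCC[C@H]1C(=O)NC(c1ccccc1)c1ccccc1` gives 6100 nM in this assay. Compound 3 `CN[C@@H](C)C(=O)N[C@@H](CCCCNc1ccc([N+](=O)[O-])cc1[N+](=O)[O-])C(=O)N1CCC[C@H]1C(=O)NC(c1ccccc1)c1ccccc1` gives 44700 nM in this assay, the highest of the three numbers; compound 1 is nearest and compound 2 furthest, both gaps beyond the scatter, so compound 3 needs the most compound of the measured set.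

Compound 4 `CN[C@@H](C)C(=O)N[C@@H](CCCCN)C(=O)N1CCC[C@H]1C(=O)NC(c1ccccc1)c1ccccc1` is not yet measured. Its difference from compound 3 is hydrogen in place of 2,4-dinitrophenyl on an amine nitrogen. Among the measured compounds shown here, compound 2 carries a hexadecanoyl amide at the same amine position and sits at the low end of the set, while the 2,4-dinitrophenyl of compound 3 sits at the high end; no step between them is given, so only their two values are known. With hydrogen at that amine, the expected step is a 2.2-fold lower number from compound 3 to compound 4 (0.35 log units; beyond the scatter), a moderate move downward, beyond the scatter but uncertain in size. Compound 4 is estimated at 20000 nM, within a range from 5000 nM to 80000 nM.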

Compound 4, half-maximal effective concentration: > 100000 nM
Compound 4: a limit, no number; the forecaster's own chance of this, stated with the estimate: 15%; at least 5.0-fold (0.69 log units) between middle value and limit.
By their numbers in this assay, from the lowest: compounds 2 and 1 (each within the scatter of the next); then compound 3. At a limit, above all of these: compound 4.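

In this assay, compound 4, with hydrogen on the amine nitrogen, stands at a limit, > 100000 nM, and not at a number. Replacing 2,4-dinitrophenyl with hydrogen gives an at least 2.2-fold higher number from compound 3 to compound 4 (0.34 log units; beyond the scatter), so the earlier picture of compound 3 as the high end of the set no longer holds, and the unsubstituted amine now sits beyond it. The two groups measured on this nitrogen, the hexadecanoyl amide of compound 2 and the 2,4-dinitrophenyl of compound 3, both give lower numbers than hydrogen, and the size of that gap rests on a limit: the limit of > 100000 nM in this assay, at which 1 of the 4 values shown sits.

The compounds shown leave open whether the chain or the aromatic ring matters more at this nitrogen. An acetyl amide, an octanoyl amide or a plain phenyl group there would help separate these two features.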